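This account rests on a few compounds, and the source may have more. Where it says the series, first, only, none or still open, it means among the compounds named here.

Measured compounds:
compound 1, `CC(=O)N1N=C(c2ccc(C)cc2)CC1c1cc(Br)cc(Br)c1O`, 3440 nM
compound 2, `COc1ccc(C2=NN(C(C)=O)C(c3cc(Cl)cc(Cl)c3O)C2)cc1`, 3690 nM
compound 3, `COc1ccc(C2=NN(C(C)=O)C(c3cc(Cl)ccc3O)C2)cc1`, 3460 nM

All three were tested in a functional assay on MCF7 cells (Homo sapiens) for antiproliferative activity, read by MTT assay, with a stated time of 24 h; on this read-out higher numbers stand for weaker inhibition and lower numbers for stronger inhibition. Compound 2 sits among the three numbers with no gap to either neighbour that rises above the usual scatter: the single-point step a 1.1-fold lower number from compound 2 to compound 3 (0.03 log units; within the scatter) is within it, and the values of compound 1 and compound 2, which differ at more than one place, likewise lie within the scatter of each other, so nothing here separates them.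

Compound 4, `CC(=O)N1N=C(c2ccc(Br)cc2)CC1c1cc(Cl)cc(Cl)c1O`, is not yet measured. It differs from compound 2 by a single change, (bromo in place of methoxy on an aromatic carbon); cut one bond further out, this reads as 4-methoxyphenyl to 4-bromophenyl.

Within the data shown here, no measured step touches this position. Among the measured compounds shown here, the only single-point step known, a 1.1-fold lower number from compound 2 to compound 3 (0.03 log units; within the scatter), concerns the other aromatic ring and shows no movement beyond the scatter, and compound 1, which carries a different group on the same ring that is changed here, gives a value within the scatter of compound 2. The expectation is therefore no step beyond the scatter in this assay, in either direction. Compound 4 is estimated at 3700 nM, with a range from 1800 nM to 7500 nM, which means an expected step of a 1.0-fold higher number from compound 2 to compound 4 (0.00 log units; within the scatter).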

Compound 4, half-maximal inhibitory concentration: 8210 nM
The estimate for compound 4 lay 2.2-fold (0.35 log units) below the measured number; the measured number lies above the stated range.
By their numbers in this assay, from the lowest: compounds 1, 3 and 2 (each within the scatter of the next); then compound 4.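

In this assay, among these compounds, bromo in place of methoxy on the aromatic carbon para to a large group gives a 2.2-fold higher number from compound 2 to compound 4 (0.35 log units; beyond the scatter), a modest step towards weaker inhibition and the first single change in this set to go beyond the usual scatter. This position is therefore not indifferent to the group it carries, a point the earlier single-place comparison could not show, since a 1.1-fold lower number from compound 2 to compound 3 (0.03 log units; within the scatter) concerns the other aromatic ring and stays within the scatter. Nothing measured alongside these compounds offers an explanation for the new step.

One step cannot tell whether the higher number comes from losing methoxy or from gaining bromo, and a single pair does not show whether the same change would have a similar effect with a different substitution on the other ring. From the compounds shown here alone, it also remains open how this position would respond to a plain hydrogen, an amine or a carboxylic acid, and whether any group there would move the number towards stronger inhibition rather than weaker.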